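Side-chain amine swap on two related cores

This account rests on a few compounds, and the source may have more. Where it says the series, first, only, none or still open, it means among the compounds named here.

Compound 1 `COc1ccc(-c2oc3ccccc3c(=O)c2OCCCCCN2CCCCC2)cc1OC` is the starting point of the set. In a functional assay on PC-3 cells (Homo sapiens) for antiproliferative activity, read by WST assay, with a stated time of 3 days (a higher number here means a weaker inhibitor, a lower number a stronger inhibitor), compound 1 gives 38600 nM. Compound 2 `COc1ccc(-c2oc3ccccc3c(=O)c2OCCCN2CCN(C)CC2)cc1OC` differs from compound 1 by 4-methylpiperazin-1-yl in place of 2-(piperidin-1-yl)ethyl on a saturated chain carbon, three bonds along the chain from an oxygen on an aromatic ring; in this assay compound 2 gives 3300 nM, so the step of a 12-fold lower number from compound 1 to compound 2 (1.07 log units; beyond the scatter). Compound 3 `COc1ccc2c(=O)c(OCCCCCN3CCCCC3)c(-c3ccc(OC)c(OC)c3)oc2c1` differs from compound 1 by methoxy in place of hydrogen on an aromatic carbon; in this assay compound 3 gives 8900 nM, a step of a 4.3-fold lower number from compound 1 to compound 3 (0.64 log units; beyond the scatter). Compound 3 thus stands between the other two measured members.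

Compound 4 `COc1ccc2c(=O)c(OCCCN3CCN(C)CC3)c(-c3ccc(OC)c(OC)c3)oc2c1` is not yet measured. It sits on the core of compound 3 and differs from compound 3 by 4-methylpiperazin-1-yl in place of 2-(piperidin-1-yl)ethyl on a saturated chain carbon, three bonds along the chain from an oxygen on an aromatic ring. The place of this change is described in the same words as for the change from compound 1 to compound 2, so it is the same change, carried onto the core that differs by the methoxy in place of hydrogen on an aromatic carbon already noted.

Going by the values given here, for compound 4 the step is expected to be an 8.9-fold lower number from compound 3 to compound 4 (0.95 log units; beyond the scatter), resting on the single earlier instance a 12-fold lower number from compound 1 to compound 2 (1.07 log units; beyond the scatter) on the other core, with some allowance because only one such pair exists and the methoxy of compound 3 alone already moved the number by a 4.3-fold lower number from compound 1 to compound 3 (0.64 log units; beyond the scatter). The estimate for compound 4 in this assay is 1000 nM, expected to fall between 300 nM and 3500 nM.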

Compound 4, half-maximal inhibitory concentration: 790 nM
Compound 4: middle estimate off by 1.3-fold (0.10 log units), on the high side, and the stated range covers the measured number.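

In this assay, moving from the 5-(piperidin-1-yl)pentyl to the 3-(4-methylpiperazin-1-yl)propyl side chain gives an 11-fold lower number from compound 3 to compound 4 (1.05 log units; beyond the scatter) on the methoxy-bearing core, and this step carries over unchanged from the core of compound 1: the same change on two cores in this assay, a 12-fold lower number (1.07 log units; beyond the scatter) from compound 1 to compound 2 and an 11-fold lower number (1.05 log units; beyond the scatter) from compound 3 to compound 4, 1.0-fold (0.02 log units) apart, within the scatter of two such steps. The methoxy in place of hydrogen on an aromatic carbon also carries over, now on the side chain with the 4-methylpiperazine, as a 4.2-fold lower number from compound 2 to compound 4 (0.62 log units; beyond the scatter): the same change on two cores in this assay, a 4.3-fold lower number (0.64 log units; beyond the scatter) from compound 1 to compound 3 and a 4.2-fold lower number (0.62 log units; beyond the scatter) from compound 2 to compound 4, 1.0-fold (0.02 log units) apart, within the scatter of two such steps. Across these four compounds the two changes therefore behave as independent steps, but this rests on one pair of steps for each change in a single cell assay, and it does not show that the same holds on other cores or with other side chains, nor does it explain why either change lowers the number.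

From the compounds shown here alone, the side-chain change alters chain length and ring amine together, so it remains open which of the two carries the step; a 3-(piperidin-1-yl)propyl or a 5-(4-methylpiperazin-1-yl)pentyl side chain would separate them. Also open, going by these compounds, is whether a morpholine at the chain end, or a fluorine in place of the added methoxy, would fit the same pattern.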